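Chain-extended isothiocyanate analogues at a single test concentration

A few compounds are considered here, and "the series" means these few. Any claim that something is new, unique, unknown or untested is made for them only; others in the source may bear on it.

Compound 1 `CN(C)C(=O)c1cc2cnc(Nc3ccc(S(=O)(=O)NCCCCN=C=S)cc3)nc2n1C1CCCC1` is measured in a functional assay on A549 cells (Homo sapiens) for inhibition, read by CCK-8 assay, with a stated time of 72 h, tested at 10 uM (on this read-out lower numbers stand for a weaker effect and higher numbers for a stronger effect at the one concentration tested), where compound 1 gives 101%. Compound 2 `CN(C)C(=O)c1cc2cnc(Nc3ccc(S(=O)(=O)NCCCCCN=C=S)cc3)nc2n1C1CCCC1` carries the change (a group of 4 heavy atoms (2 carbon, 1 nitrogen, 1 sulfur; no ring) in place of a group of 3 heavy atoms (1 carbon, 1 nitrogen, 1 sulfur; no ring), on a saturated chain carbon, four bonds along the chain from a sulfonamide nitrogen); in this assay compound 2 gives 102%, a step of a number 1 percentage points higher from compound 1 to compound 2 (within the scatter). Compound 3 `CN(C)C(=O)c1cc2cnc(Nc3ccc(NC(=O)CCCCN=C=S)cc3)nc2n1C1CCCC1` differs from compound 1 in its core by a group of 10 heavy atoms (6 carbon, 2 nitrogen, 1 oxygen, 1 sulfur; no ring) in place of a group of 11 heavy atoms (5 carbon, 2 nitrogen, 2 oxygen, 2 sulfur; no ring), on an aromatic carbon; in this assay compound 3 gives 102%, with a number 1 percentage points higher from compound 1 to compound 3 (within the scatter) and no change at the digits printed from compound 2 to compound 3 (within the scatter). All three measured numbers lie within the scatter of one another, so no ordering among them can be read.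

Compound 4 `CN(C)C(=O)c1cc2cnc(Nc3ccc(NC(=O)CCCCCN=C=S)cc3)nc2n1C1CCCC1` is not yet measured; it differs from compound 3 by a group of 4 heavy atoms (2 carbon, 1 nitrogen, 1 sulfur; no ring) in place of a group of 3 heavy atoms (1 carbon, 1 nitrogen, 1 sulfur; no ring), on a saturated chain carbon, four bonds along the chain from a carbonyl carbon. Among the measured compounds shown here, this is the same kind of change as the one from compound 1 to compound 2, though not the same: here the place is four bonds along the chain from a carbonyl carbon, there it was four bonds along the chain from a sulfonamide nitrogen. For compound 4 the step of no change at the digits printed from compound 3 to compound 4 (within the scatter) is expected. This rests on the step of a number 1 percentage points higher from compound 1 to compound 2 (within the scatter) made by the same kind of change, and on compound 3 already giving 102%, which leaves little room upward. Compound 4 is estimated at 102%, expected between 96% and 106%.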

Compound 4, a percentage reported as inhibition, at one concentration (the size of the read-out at that concentration, not a potency): 100%
For compound 4 the middle estimate is 2 percentage points above the measured one, and the stated range covers the measured number.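

In this assay the chain change on the core of compound 3 gives a number 2 percentage points lower from compound 3 to compound 4 (within the scatter), and exchanging the whole side chain on the aromatic carbon gives a number 2 percentage points lower from compound 2 to compound 4 (within the scatter) and a number 1 percentage points lower from compound 1 to compound 4 (within the scatter). Set beside the step on the core of compound 1, the same chain change shows no difference that can be read between the two cores: the same change on two cores in this assay, a number 1 percentage points higher (within the scatter) from compound 1 to compound 2 and a number 2 percentage points lower (within the scatter) from compound 3 to compound 4, 3 percentage points apart, within the scatter of two such steps. Among the compounds shown here, this shows only that the change leaves the read-out within the scatter on both cores at the one concentration tested; it does not show that the cores would respond alike at other concentrations, and a percentage at one concentration gives no potency.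

The compounds shown leave open whether a chain ending in a group other than the isothiocyanate, such as an amine or a carboxylic acid, would give a read-out in the same range. They also leave open what a much longer chain on either core would do.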